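Adding a Methoxy Group to Compound 2

This account rests on a few compounds, and the source may have more. Where it says the series, first, only, none or still open, it means among the compounds named here.

Measured so far:
compound 1 `COc1ccc(/C=C/C2CC=CC(=O)O2)c(OC)c1` gives 4.6 uM
compound 2 `COc1ccc(/C=C/C2CC=CC(=O)O2)cc1OC` gives 23.9 uM
compound 3 `COc1cc(/C=C/C2CC=CC(=O)O2)cc(OC)c1OC` gives 25.1 uM

In a functional assay on U-251 cells (Homo sapiens) for inhibition, read by sulforhodamine B assay, with a stated time of 48 h (a lower number here means a stronger inhibitor of growth, a higher number a weaker inhibitor of growth), compound 2 stands with the second highest of the three numbers; compound 3 is nearest, and compound 1 furthest with its clearly lower number. Compound 4 `COc1cc(OC)c(OC)cc1/C=C/C1CC=CC(=O)O1` is not yet measured. It differs from compound 2 by methoxy in place of hydrogen on an aromatic carbon. Going by the values given here, one measured step bears on this kind of change: a 1.1-fold higher number from compound 2 to compound 3 (0.02 log units; within the scatter), which also added a methoxy group to compound 2 and left the number essentially where it was. The step to compound 4 is therefore expected to be small, a 1.3-fold lower number from compound 2 to compound 4 (0.12 log units; within the scatter), with no clear direction. Compound 4 is estimated at 18 uM, within a range of 6 uM to 45 uM.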

Compound 4, concentration for growth inhibition (reported as GI): 11.5 uM
Beside the measured number, compound 4's estimate is 1.6-fold (0.19 log units) above it, and the stated range covers the measured number.
By their numbers in this assay, from the lowest: compound 1; then compound 4; then compounds 2 and 3 (each within the scatter of the next).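

In this assay, methoxy in place of hydrogen ortho to a group of 9 heavy atoms gives a 2.1-fold lower number from compound 2 to compound 4 (0.32 log units; beyond the scatter), whereas the earlier methoxy addition gave a 1.1-fold higher number from compound 2 to compound 3 (0.02 log units; within the scatter), so on this core the outcome is not the same at every position. On another core, the same kind of change runs the other way: a 2.5-fold higher number from compound 1 to compound 4 (0.40 log units; beyond the scatter). Even so, the two steps that add a methoxy group to different cores cannot be told apart: the same change on two cores in this assay, a 1.1-fold higher number (0.02 log units; within the scatter) from compound 2 to compound 3 and a 2.5-fold higher number (0.40 log units; beyond the scatter) from compound 1 to compound 4, 2.4-fold (0.38 log units) apart, within the scatter of two such steps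

On these data alone, whether a hydroxyl group, an amine or a longer chain at this position would shift growth inhibition further remains open.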